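This account rests on a few compounds, and the source may have more. Where it says the series, first, only, none or still open, it means among the compounds named here.

Measured so far in an ADME assay on microsomes from liver (Macaca fascicularis) for metabolic stability, read by LC-MS, with a stated time of 65 min, tested at 1 uM; on this read-out higher numbers stand for a more stable compound and lower numbers for a less stable compound
- compound 1 `Cc1ncncc1-c1nc2cc(F)c(F)cc2n1C1CC1` gives 72%
- compound 2 `CN(C)c1ncncc1-c1nc2cc(F)c(F)cc2n1C1CC1` gives 6%

Compound 2 stands at 6% and holds the lower of the two numbers. Within the data shown here, the only measured step bearing on the next change is a number 66 percentage points lower from compound 1 to compound 2 (beyond the scatter) and it is large, with dimethylamino in place of methyl on an aromatic carbon. Compound 3 `Fc1cc2nc(-c3cncnc3C(F)F)n(C3CC3)c2cc1F` has difluoromethyl in place of dimethylamino on that same aromatic carbon difluoromethyl in place of dimethylamino on an aromatic carbon and so loses the group that marks compound 2. Among the measured compounds shown here, no compound with difluoromethyl has been measured, so the expectation rests on this single step. A large upward move is expected, somewhat smaller than the measured one and beyond the scatter. The estimated step is a number 54 percentage points higher from compound 2 to compound 3 (beyond the scatter) in this series. For compound 3 the estimated value is 60% with an expected range from 35% to 85% in this assay.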

Compound 3, percent of the compound remaining: 106%
Estimate against measurement, compound 3: 46 percentage points below, and the stated range ends below it.
By their numbers in this assay, from the lowest: compound 2; then compound 1; then compound 3.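

In this assay the group on this aromatic carbon of the six-membered aromatic ring with 2 nitrogen now spans three measured cases, and difluoromethyl in place of dimethylamino gives a number 100 percentage points higher from compound 2 to compound 3 (beyond the scatter) with the shared core unchanged. Difluoromethyl in place of methyl gives a number 34 percentage points higher from compound 1 to compound 3 (beyond the scatter) and so shows that methyl did not mark the top of the range at this place, the order from the lowest being dimethylamino, methyl, difluoromethyl. Nothing at hand accounts for this order.

Open, as far as these compounds go, is how a trifluoromethyl, a methoxy or a cyclopropyl on this same carbon would compare, and whether a smaller amine such as methylamino shares the low number of compound 2. Also open, from the compounds shown here alone, is whether this order of the three groups holds when the cyclopropyl or the two fluorines on the shared core are replaced.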